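The compounds below may be only part of what the source reports. "The series", "measured", "known", "first", "only" and "open" are said of these compounds alone.

Measured compounds:
compound 1 `CC(C)(C)OC(=O)NC1CCN(C(=O)CN2CN(c3ccccc3)C3(CCN(C(=O)c4ccc(C(C)(C)C)cc4)CC3)C2=O)CC1` — 8300 nM
compound 2 `CC(C)(C)c1ccc(C(=O)N2CCC3(CC2)C(=O)N(CC(=O)N2CCC(O)CC2)CN3c2ccccc2)cc1` — 4700 nM
compound 3 `CCc1nn(CC)c(C2CCN(C(=O)CN3CN(c4ccccc4)C4(CCN(C(=O)c5ccc(C(C)(C)C)cc5)CC4)C3=O)CC2)c1C` — 2500 nM

All three numbers come from an assay on HEK293 cells for displacement of a labelled ligand from NPC1-like intracellular cholesterol transporter 1 (Homo sapiens); a lower number here means a stronger inhibitor, a higher number a weaker inhibitor. Compound 3 gives the lowest number of the three. One of its steps is a 1.9-fold lower number from compound 2 to compound 3 (0.27 log units; within the scatter), which stays within the scatter, while the other is a 3.3-fold lower number from compound 1 to compound 3 (0.52 log units; beyond the scatter), which lies beyond it. Between the other two the step is a 1.8-fold lower number from compound 1 to compound 2 (0.25 log units; within the scatter).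

Compound 4 `CC(C)(C)OC(=O)NCC1CCN(C(=O)CN2CN(c3ccccc3)C3(CCN(C(=O)c4ccc(C(C)(C)C)cc4)CC3)C2=O)CC1` has not yet been measured. It differs from compound 3 in one place: ((tert-butoxycarbonyl)amino)methyl in place of 1,3-diethyl-4-methyl-1H-pyrazol-5-yl on a saturated ring carbon. The entering group is a chain-extended form of the (tert-butoxycarbonyl)amino that compound 1 carries directly on the ring carbon. Within the data shown here, the only measured step that bears on this change is a 3.3-fold lower number from compound 1 to compound 3 (0.52 log units; beyond the scatter), here run in the opposite direction; nothing measured says whether the added linking carbon shifts the number on its own. Compound 4 is therefore expected to return toward the number of compound 1. For compound 4 the expected step in this assay is a 2.8-fold higher number from compound 3 to compound 4 (0.45 log units; beyond the scatter), a higher number that may reach beyond the scatter. The estimate for compound 4 is 7000 nM, with a range of 2500 nM to 20000 nM.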

Compound 4, half-maximal inhibitory concentration: 4200 nM
The estimate for compound 4 lay 1.7-fold (0.22 log units) above the measured number; measured number inside the range.
By their numbers in this assay, from the lowest: compounds 3, 4, 2 and 1 (each within the scatter of the next, the first and the last beyond it).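

In this assay the step of a 1.7-fold higher number from compound 3 to compound 4 (0.23 log units; within the scatter) leaves ((tert-butoxycarbonyl)amino)methyl, a group with no ring, indistinguishable from 1,3-diethyl-4-methyl-1H-pyrazol-5-yl on this saturated ring carbon, and the step of a 1.1-fold lower number from compound 2 to compound 4 (0.05 log units; within the scatter) leaves it equally indistinguishable from hydroxy. The step of a 2.0-fold lower number from compound 1 to compound 4 (0.30 log units; within the scatter) gives the added linking carbon no readable shift of its own, and with compound 4 within the scatter of each of the other three compounds, the separation of compound 1 from compound 3 remains the only one beyond the scatter at this position. No measurement shown here bears on the reason for any of these steps.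

On these data alone, whether a free primary amine or a carboxylic acid on the same ring carbon, or a longer chain carrying the tert-butoxycarbonyl group, would give a number beyond the scatter of compound 3 remains open. As far as these compounds go, all four compounds also keep the phenyl and the 4-tert-butylbenzoyl parts of the shared core unchanged, so it is equally open whether this ring carbon would behave the same with other groups there.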